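Aryl Group Swaps on the Sulfonyl Sulfur: Three Measured, One Expected

The source may hold more compounds than are shown below. What is called first, only, known or untested is meant among the compounds shown, and "the series" means these compounds.

Three compounds have been measured in an assay on isolated protein for displacement of a labelled ligand from metabotropic glutamate receptor 5 (Homo sapiens), with a stated time of 60 min, tested at 1 uM; a higher number here means more inhibition at the concentration tested (going by the name of the read-out), a lower number less inhibition:
Compound 1 `Cc1ccc(S(=O)(=O)c2cnc3cc(Cl)ccc3c2N2CCC(C)CC2)cc1F` gives 85%.
Compound 2 `CC1CCN(c2c(S(=O)(=O)c3cc(F)cc(F)c3)cnc3cc(Cl)ccc23)CC1` gives 94%.
Compound 3 `Cc1ccc(S(=O)(=O)c2cnc3cc(Cl)ccc3c2N2CCC(C)CC2)cc1Cl` gives 89%.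

Compound 3 stands second highest of the three numbers. Its nearest neighbour is compound 1, with a number 4 percentage points higher from compound 1 to compound 3 (within the scatter), and the furthest is compound 2, with a number 5 percentage points lower from compound 2 to compound 3 (within the scatter); both of these steps lie within the scatter, so the three compounds are indistinguishable on the numbers shown.

Compound 4 `COc1ccc(S(=O)(=O)c2cnc3cc(Cl)ccc3c2N2CCC(C)CC2)cc1` differs from compound 3 at one place only: 4-methoxyphenyl in place of 3-chloro-4-methylphenyl on a sulfonyl sulfur. Among the measured compounds shown here, two measured steps bear on this change, since each also exchanges the aryl group on the sulfonyl sulfur: a number 9 percentage points higher from compound 1 to compound 2 (within the scatter) and a number 5 percentage points lower from compound 2 to compound 3 (within the scatter). Both are within the scatter, so the three aryl groups tried so far have given no step beyond it. For the measured compounds named here, no measured compound carries a 4-methoxyphenyl group on the sulfonyl sulfur, which leaves the expectation less certain than those two steps alone would suggest. The step expected for compound 4 is a number 7 percentage points lower from compound 3 to compound 4 (within the scatter), that is, none beyond the scatter, with a range wide enough to allow a modest drop. Compound 4 is therefore estimated at 82%, with a range from 62% to 95%.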

Compound 4, a percentage reported as inhibition, at one concentration (the size of the read-out at that concentration, not a potency): 79%
Compound 4: the middle estimate sits 3 percentage points above what was measured; the measured number falls inside the stated range.
By their numbers in this assay, from the lowest: compounds 4, 1, 3 and 2 (each within the scatter of the next, the first and the last beyond it).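

Among the aryl groups on the sulfonyl sulfur, 4-methoxyphenyl gives the first step at this position that goes beyond the scatter, a change seen only against 3,5-difluorophenyl: a number 15 percentage points lower from compound 2 to compound 4 (beyond the scatter). The other two steps, a number 10 percentage points lower from compound 3 to compound 4 (within the scatter) and a number 6 percentage points lower from compound 1 to compound 4 (within the scatter), stay within it, so in this assay the aryl group is shown to matter only for the pair of compound 2 and compound 4, and only modestly. The change from 3-chloro-4-methylphenyl to 4-methoxyphenyl exchanges chlorine for oxygen and adds a hydrogen-bond acceptor by count, but nothing available accounts for any of these differences.

The compounds shown leave open whether an aryl group carrying an amine or a carboxylic acid, or a 4-ethoxyphenyl group, would stay within the scatter of these four on the sulfonyl sulfur. They also leave open how far these steps reflect differences in potency, since each number comes from a single tested concentration.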